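Urea to amide swap in a tetrahydroquinoline series

The source may hold more compounds than are shown below. What is called first, only, known or untested is meant among the compounds shown, and "the series" means these compounds.

Notes on a small set of melatonin-receptor compounds. Compound 1 `CCC(=O)NCCC1CCc2ccccc2N1Cc1ccccc1` has no result reported in a functional assay on CHO cells with melatonin receptor type 1A (Homo sapiens) as the target, read by GTPgammaS binding, with a stated time of 1 h (a higher number here means a larger maximal response, a lower number a smaller maximal response), where compound 1 stands as "not determined" (no result reported). Compound 2 `CCC(=O)NCc1ccc2c(OC)cccc2n1` likewise has no result reported in this assay, where compound 2 stands as "not determined" (no result reported). Within the data shown here, compound 3 `CCNC(=O)NCC1CCc2ccccc2N1` is the only member with a number: in this assay compound 3 gives 30%, so it stands alone, and no comparison between measured compounds is available.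

Compound 4 `CCC(=O)NCC1CCc2ccccc2N1` has not been measured. The change from compound 3 is ethyl in place of ethylamino on a carbonyl carbon. Among the measured compounds shown here, with no measured step to lean on, the expectation is a moderate rise in this assay, a step of a number 25 percentage points higher from compound 3 to compound 4 (beyond the scatter) beyond the scatter, though the direction rests on the change alone. Compound 4 is estimated at 55% in this assay, within 25% to 90%.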

Compound 4, largest response reached (Emax), in percent of the reference or control that the assay uses: 37%
The estimate for compound 4 lay 18 percentage points above the measured number, and the stated range covers the measured number.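

Swapping ethylamino for ethyl on a carbonyl carbon gives, in this assay, a number 7 percentage points higher from compound 3 to compound 4 (within the scatter) as the first readable step in the series. This position therefore tolerates the ethylcarbamoyl to propanoyl change, and the hydrogen-bond donor that leaves with ethylamino separates the two compounds by no more than the scatter. No supporting data bear on this result.

As far as these compounds go, whether a longer chain such as butyl or a smaller group such as methyl on this carbonyl carbon would move the maximal response remains open. A single step also cannot show whether the same swap behaves alike on other cores.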